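Chain extension from compound 1 to compound 3

A few compounds are considered here, and "the series" means these few. Any claim that something is new, unique, unknown or untested is made for them only; others in the source may bear on it.

Measured in a functional assay on B16 cells (Mus musculus) for inhibition, read by MTT assay, with a stated time of 48 h; a higher number here means a weaker inhibitor, a lower number a stronger inhibitor:
- compound 1 `O=C(CCCOC(=O)c1ccc2c(c1)no[n+]2[O-])NO`: 22200 nM
- compound 2 `O=C(CCCCCOC(=O)c1ccc2c(c1)no[n+]2[O-])NO`: 30300 nM

Compound 1 and compound 2 are the only two measured points and lie within the scatter of each other, so no order can be drawn between them. The next compound to read is compound 3 `O=C(CCCCCCOC(=O)c1ccc2c(c1)no[n+]2[O-])NO`. The change is 3-(hydroxycarbamoyl)propyl in place of hydroxycarbamoyl on a saturated chain carbon, three bonds along the chain from an oxygen next to a carbonyl group.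

For the measured compounds named here, one measured step bears on this, with 2-(hydroxycarbamoyl)ethyl entering at the same place: a 1.4-fold higher number from compound 1 to compound 2 (0.14 log units; within the scatter). On these data alone, that single step is thin evidence, and the 3-(hydroxycarbamoyl)propyl group itself is untested. With compound 2 at 30300 nM as the closest guide, no step beyond the scatter is expected in this assay, and no direction can be favoured. The expected size of the change is a 1.2-fold higher number from compound 1 to compound 3 (0.07 log units; within the scatter). For compound 3 the estimate is 26000 nM, with an expected range of 10000 nM to 60000 nM.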

Compound 3, half-maximal inhibitory concentration: 4970 nM
For compound 3 the middle estimate is 5.2-fold (0.72 log units) above the measured one; the measured number lies below the stated range.
By their numbers in this assay, from the lowest: compound 3; then compounds 1 and 2 (each within the scatter of the next).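

In this assay, for the compounds shown here, 3-(hydroxycarbamoyl)propyl in place of hydroxycarbamoyl, on a saturated chain carbon, three bonds along the chain from an oxygen next to a carbonyl group, gives a 4.5-fold lower number from compound 1 to compound 3 (0.65 log units; beyond the scatter), the first step at this position to lie beyond the scatter. Seen from compound 2, (hydroxycarbamoyl)methyl in place of hydroxycarbamoyl, on a saturated chain carbon, five bonds along the chain from an oxygen next to a carbonyl group, gives a 6.1-fold lower number from compound 2 to compound 3 (0.79 log units; beyond the scatter), so the chain is not without effect, yet the response is not a steady one across the three compounds: compound 1 and compound 2 cannot be told apart, and only compound 3 stands apart from both. Nothing shown here accounts for this step.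

On these data alone, whether a longer chain than that of compound 3 lowers the number in this assay further or reverses the step remains open. Also open, as far as these compounds go, is whether the lower number at compound 3 depends on the hydroxycarbamoyl end, which a carboxylic acid at the same chain end would test.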